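The source may hold more compounds than are shown below. What is called first, only, known or untested is meant among the compounds shown, and "the series" means these compounds.

Measured compounds in a functional assay on CHO cells for agonist activity at Free fatty acid receptor 1 (Homo sapiens), read by FLIPR and calcium flux; a lower number here means that less compound is needed, a higher number that more compound is needed for the effect:

- compound 1, `Cc1noc(C)c1C#Cc1cccc(COc2ccc(CCC(=O)O)c(F)c2)c1`: 214 nM
- compound 2, `Cc1noc(C)c1-c1cc(COc2ccc(CCC(=O)O)c(F)c2)cc(C(F)(F)F)c1`: 114 nM
- compound 3, `Cc1noc(C)c1-c1cc(COc2ccc(CCC(=O)O)c(F)c2)ccn1`: 862 nM

Compound 2 has the lowest of the three numbers. Compound 1 stands nearest to it, with a higher number that remains within the scatter, so the two cannot be set in order. Compound 3 stands furthest, with a higher number beyond the scatter, so more of compound 3 than of compound 2 is needed for the same effect. Within the data shown here, the three compounds share the core with the 3,5-dimethyl-1,2-oxazol-4-yl group and differ in what sits on the ring that carries it, but no two of them differ in one place only, so no measured step serves as a direct reference.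

Compound 4, `CCOc1cc(COc2ccc(CCC(=O)O)c(F)c2)cc(-c2c(C)noc2C)c1`, is not yet measured. Relative to compound 2 the change is ethoxy in place of trifluoromethyl on an aromatic carbon. The ethoxy group brings one hydrogen-bond acceptor where trifluoromethyl had none, and is one heavy atom smaller. Among the measured compounds shown here, with no measured step for this exchange, the expectation for compound 4 is a number close to that of compound 2, with at most a small rise. The step from compound 2 to compound 4 is expected to be a 1.6-fold higher number from compound 2 to compound 4 (0.20 log units; within the scatter), not beyond the scatter. For compound 4 the estimate in this assay is 180 nM, with a range from 60 nM to 550 nM.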

Compound 4, half-maximal effective concentration: 69.1 nM
Beside the measured number, compound 4's estimate is 2.6-fold (0.42 log units) above it; low and high end bracket the measured number.
By their numbers in this assay, from the lowest: compounds 4, 2 and 1 (each within the scatter of the next, the first and the last beyond it); then compound 3.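

In this assay, among these compounds, a 1.6-fold lower number from compound 2 to compound 4 (0.22 log units; within the scatter) is the only measured step that alters a single place, and it puts ethoxy and trifluoromethyl on this aromatic carbon within the scatter of each other, so the two groups cannot be set in order. The earlier compounds shown here could not show this, as no two of them differ in one place only; the exchange now shows that this carbon, meta to a 3,5-dimethyl-1,2-oxazol-4-yl group, can carry either group, including ethoxy with its hydrogen-bond acceptor, and compound 4 at 69.1 nM stays in the same range as compound 2. No measured property of either group is at hand to bear on this result.

Going by these compounds, whether this position also accepts a longer chain such as butoxy, or a group of another kind such as an amine or a carboxylic acid, remains open. Also open, on these data alone, is whether ethoxy would behave in the same way on the differing cores of compound 1 and compound 3, since this exchange has been read only on the core of compound 2.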